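Changing Two Stereo Elements of Compound 1

The source may report more compounds than this note shows. Statements on the series, on what has been measured and on what is new or still open speak of the compounds shown alone.

Among the compounds with values here, only two compounds have numbers so far. In an ADME assay on Akata cells (Homo sapiens) for cytotoxicity (on this read-out lower numbers stand for higher toxicity in this test and higher numbers for lower toxicity in this test), compound 1 (`Nc1ncnc2c1ncn2/C=C1\C[C@H]1[C@H](O)CO`) gives 72700 nM as its reading, and compound 2 (`Nc1nc2c(ncn2/C=C2/CC2(CO)CO)c(=O)[nH]1`) gives 46000 nM as its reading. These readings lie within the usual scatter of each other, so the numbers do not separate the two compounds.

Compound 3 (`Nc1ncnc2c1ncn2/C=C1/C[C@@H]1[C@H](O)CO`) is still to be tested. It has the same atoms and bonds as compound 1 and differs only in configuration as drawn, meaning how the same parts are arranged in space. The difference is the two compounds have the same atoms and bonds and differ only in configuration as drawn: 2 of 3 stereo elements differ; a stereocentre at a saturated ring carbon is drawn R in compound 1 and S in compound 3; a double bond is drawn E in compound 1 and Z in compound 3 in total: a stereocentre at a saturated ring carbon is drawn R in compound 1 and S in compound 3, and a double bond is drawn E in compound 1 and Z in compound 3.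

Within the data shown here, no measured pair shows what such a change does in this test, so no step beyond the scatter is expected in either direction. The estimated change is a 1.2-fold lower number from compound 1 to compound 3 (0.08 log units; within the scatter) and would stay within the scatter. Compound 3 is expected to read 60000 nM in this assay with an estimated range from 20000 nM to 160000 nM around that figure.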

Compound 3, half-maximal cytotoxic concentration: 50500 nM
Beside the measured number, compound 3's estimate is 1.2-fold (0.07 log units) above it, and the stated range covers the measured number.
By their numbers in this assay, from the lowest: compounds 2, 3 and 1 (each within the scatter of the next).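

Within the data shown here, compounds 1 and 3 give the first step in this set that can be read directly, and it isolates the arrangement of the parts in space from any change in the parts themselves: the fact that compounds 1 and 3 differ only in the configuration as drawn. In this assay, switching the stereocentre at the saturated ring carbon from R to S and the double bond from E to Z together gives a 1.4-fold lower number from compound 1 to compound 3 (0.16 log units; within the scatter). This combined change therefore does not separate the two compounds in this test, so for this pair, the drawn configuration at these two places has no effect that can be told apart from ordinary repeat variation.

The two stereo elements change together here, so the compounds shown cannot tell what either would do alone, and two opposing effects that cancel each other cannot be ruled out. Going by these compounds, it also remains open whether the reading would stay this flat if a hydroxyl group gave way to a different group, such as an amine or a carboxylic acid.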